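The source may hold more compounds than are shown below. What is called first, only, known or untested is meant among the compounds shown, and "the series" means these compounds.

Measured in a functional assay on MT4 cells (Homo sapiens) for cytotoxicity, read by MTT assay; on this read-out higher numbers stand for lower toxicity in this test and lower numbers for higher toxicity in this test:
Compound 1 `Cc1c(O)nc(SCc2ccccc2)nc1Cc1c(Cl)cccc1Cl`: > 64000 nM, a limit.
Compound 2 `Cc1c(O)nc(SCc2ccc([N+](=O)[O-])cc2)nc1Cc1c(Cl)cccc1Cl`: > 58000 nM, a limit.
Compound 3 `Cc1c(O)nc(SCc2ccc(F)cc2)nc1Cc1c(Cl)cccc1Cl`: > 61000 nM, a limit.

Compound 3 is known only through its limit of > 61000 nM, and the other two values are limits as well. Compound 4 `CCCCOc1ccc(CSc2nc(O)c(C)c(Cc3c(Cl)cccc3Cl)n2)cc1` differs from it by butoxy in place of fluoro on an aromatic carbon. The measured steps closest to this change are a step that the two limits leave unreadable from compound 1 to compound 3 and a step that the two limits leave unreadable from compound 2 to compound 3, and a step that the two limits leave unreadable from compound 1 to compound 2 also bears on it. Among the compounds with values here, none of these gives a size, and no butoxy compound has been measured. A small move towards lower numbers in this assay is therefore expected, with no firm step beyond the scatter. The expected change is an at least 1.3-fold lower number from compound 3 to compound 4 (0.13 log units; that floor lies within the scatter). Compound 4 is estimated at 45000 nM, with an expected range of 15000 nM to 80000 nM.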

Compound 4, half-maximal cytotoxic concentration: 3100 nM
Compound 4: the middle estimate sits 15-fold (1.16 log units) above what was measured; the whole stated range lies above it.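

Butoxy, on the aromatic carbon para to a large group, is the first substituent here to give a readable number in this assay for this series, while the steps among compound 1, compound 2 and compound 3 cannot be read. The change gives an at least 19-fold lower number from compound 3 to compound 4 (1.29 log units; beyond the scatter) and an at least 18-fold lower number from compound 2 to compound 4 (1.27 log units; beyond the scatter) and an at least 20-fold lower number from compound 1 to compound 4 (1.31 log units; beyond the scatter) with each step beyond the scatter. These sizes are only floors because compound 3 rests on a limit, as do compound 1 and compound 2: the limit of > 61000 nM in this assay, at which 1 of the 4 values shown sits.

Open, as far as these compounds go, is whether the oxygen or the chain carries the step. A plain butyl chain and a methoxy group at this place would separate the two.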